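Swapping an Aromatic Amine for a Saturated Ring

The compounds below may be only part of what the source reports. "The series", "measured", "known", "first", "only" and "open" are said of these compounds alone.

Of the compounds shown here, two with a shared core have been tested in an ADME assay on MT4 cells (Homo sapiens) for cytotoxicity, read by MTT assay, with a stated time of 4 days; a higher number here means that more compound is tolerated, a lower number that less compound is tolerated. Compound 1 `O=c1cc(Cc2c(F)cccc2F)nc(N2CCC3(CC2)OCCO3)[nH]1` was tolerated up to the top of the tested range, so its result is only a limit, > 69000 nM. Compound 2 `Cc1c(Cc2c(F)cccc2F)nc(N(C)c2ccccc2)[nH]c1=O` likewise gives only a limit, > 73000 nM. Compound 2 therefore stands at the upper edge of what this assay can report, where compound 1 also sits, and no numbered step between the two is known.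

Compound 3 `Cc1c(Cc2c(F)cccc2F)nc(N2CCC(C)CC2)[nH]c1=O` differs from compound 2 in a single place: 4-methylpiperidin-1-yl in place of methyl(phenyl)amino on an aromatic carbon. Within the data shown here, no measured pair shows what such a change does here, so the expectation rests on compound 2 alone, whose result is a limit. The step is expected to be a step that the limit leaves unreadable from compound 2 to compound 3, that is, no shift beyond the usual scatter. Compound 3 is estimated at 80000 nM, within a range from 40000 nM to 200000 nM, and is expected most likely to return only a limit as well.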

Compound 3, half-maximal cytotoxic concentration: > 75000 nM
Compound 3: no number, only a limit (the forecaster's own chance of this, stated with the estimate: 80%); the middle value is on the limit's open side.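

Compound 2 and compound 3 both return only a limit rather than a number, so the change between them cannot be read as a step of any size. The compounds shown leave open at what concentration, if any, each one begins to harm the cells.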